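The source may report more compounds than this note shows. Statements on the series, on what has been measured and on what is new or still open speak of the compounds shown alone.

Measured compounds:
compound 1, `CCn1c(/C=C2/C(=O)Nc3ccc(C)cc32)nc2ccccc21`, 38600 nM
compound 2, `CC(C)n1c(/C=C2/C(=O)Nc3ccc(Cl)cc32)nc2ccccc21`, 38100 nM
compound 3, `Cn1c(/C=C2/C(=O)Nc3ccc(F)cc32)nc2ccccc21`, 34300 nM

In a functional assay on PC-3 cells (Homo sapiens) for cytotoxicity, read by MTT assay, with a stated time of 48 h (on this read-out higher numbers stand for weaker inhibition and lower numbers for stronger inhibition), compound 1 gives the highest of the three numbers, yet its gaps to compound 2 and to compound 3 both lie within the scatter, so the three compounds cannot be told apart on these numbers. Compound 4, `CCn1c(/C=C2/C(=O)Nc3ccc([N+](=O)[O-])cc32)nc2ccccc21`, has not been measured; it differs from compound 1 as follows: nitro in place of methyl on an aromatic carbon. Among the measured compounds shown here, no measured pair shows this change, so its size is unknown. With all three measured compounds sitting together, compound 4 is expected to stay near them, with a step from compound 1 to compound 4 of a 1.1-fold lower number from compound 1 to compound 4 (0.04 log units; within the scatter), not beyond the scatter. Compound 4 is therefore estimated at 35000 nM, between 12000 nM and 100000 nM.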

Compound 4, half-maximal inhibitory concentration: 40100 nM
For compound 4 the middle estimate is 1.1-fold (0.06 log units) below the measured one; the measured number falls inside the stated range.
By their numbers in this assay, from the lowest: compounds 3, 2, 1 and 4 (each within the scatter of the next).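

In this assay, among the compounds shown here, this is the first single-place comparison on the shared core: nitro in place of methyl on this aromatic carbon gives a 1.0-fold higher number from compound 1 to compound 4 (0.02 log units; within the scatter) and so brings no separable change, although the group entering has more heavy atoms and two hydrogen-bond acceptors. The earlier compounds shown here differ in more than one place and could not isolate this exchange. Nothing measured here bears on the reason for this result. From the compounds shown here alone, whether an amine or a carboxylic acid in this place would give a step beyond the scatter stays open.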